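Shortening an ether side chain: isobutyl to isopropyl

The compounds below may be only part of what the source reports. "The series", "measured", "known", "first", "only" and "open" are said of these compounds alone.

Measured so far:
compound 1 `CC(C)COc1ccc2c(Cl)ccnc2c1`: 3030 nM
compound 2 `Clc1ccnc2cc(OCCc3ccccc3)ccc12`: 2010 nM

In a functional assay on BGC-823 cells (Homo sapiens) for cytotoxicity, read by MTT assay, with a stated time of 48 h (on this read-out higher numbers stand for weaker inhibition and lower numbers for stronger inhibition), compound 1 gives 3030 nM, which is the upper of the two numbers shown. Compound 2 gives 2010 nM in this assay, and the gap between the two lies within the usual scatter, so on these data the two cannot be told apart.

Compound 3 `CC(C)Oc1ccc2c(Cl)ccnc2c1` has not yet been tested. It differs from compound 1 in one place: isopropyl in place of isobutyl on an oxygen on an aromatic ring. For the measured compounds named here, no measured pair shows this change, so there is nothing in the data to say which way, if any, the number should move. The expectation is therefore a step of no size beyond the scatter, a 1.0-fold lower number from compound 1 to compound 3 (0.00 log units; within the scatter), in this assay. On that basis compound 3 is estimated at 3000 nM, with a range from 1200 nM to 7500 nM.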

Compound 3, half-maximal inhibitory concentration: 2630 nM
The estimate for compound 3 lay 1.1-fold (0.06 log units) above the measured number; low and high end bracket the measured number.
By their numbers in this assay, from the lowest: compounds 2, 3 and 1 (each within the scatter of the next).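

In this assay, for the compounds shown here, isopropyl in place of isobutyl on an oxygen on an aromatic ring gives a 1.2-fold lower number from compound 1 to compound 3 (0.06 log units; within the scatter) and this is the first one-place change measured at this position. Going from 4 heavy atoms in the chain to 3 therefore leaves the number indistinguishable from that of compound 1, so this small trim of the branched chain brings neither a detectable gain nor a detectable loss. Nothing available explains why the result came out this way.

Still open, from the compounds shown here alone, is whether a methyl group, a much longer chain, or a chain ending in an amine or a carboxylic acid would move the number beyond the scatter. A single step also cannot show whether this same swap would behave alike on a different core.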